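Ethylsulfanyl acetamide analogue in the macrophage cytotoxicity series

This account rests on a few compounds, and the source may have more. Where it says the series, first, only, none or still open, it means among the compounds named here.

Measured so far:
compound 1 `O=C(CCl)Nn1c(COc2ccccc2C2=NOC(c3ccc(Cl)cc3Cl)C2)nnc1Sc1ccccc1`: "not determined" (no result reported)
compound 2 `CCSc1nnc(COc2ccccc2C2=NOC(c3ccc(Cl)cc3Cl)C2)n1NC(=O)c1ccccc1`: 1.8 ug/mL
compound 3 `CCOC(=O)CSc1nnc(COc2ccccc2C2=NOC(c3ccc(Cl)cc3Cl)C2)n1NC(C)=O`: "not determined" (no result reported)

All three compounds share one core and are read in an ADME assay (MDM cells, Homo sapiens) for cytotoxicity, read by resazurin assay, with a stated time of 3 days; a higher number here means a weaker inhibitor, a lower number a stronger inhibitor. Only compound 2 gives a number there, 1.8 ug/mL. For compound 1 the read-out is "not determined" (no result reported), and for compound 3 it is likewise "not determined" (no result reported), so compound 3 stands without a single number and is one of two such entries in the set. Among the compounds with values here, no step between two measured compounds can be computed from these data.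

The next compound is compound 4 `CCSc1nnc(COc2ccccc2C2=NOC(c3ccc(Cl)cc3Cl)C2)n1NC(C)=O`. It differs from compound 3 in one place: methyl in place of ethoxycarbonyl on a saturated chain carbon bound to a sulfur. Since compound 3 has no number, the size of the step from compound 3 to compound 4 in this assay cannot be read from what is in hand. The nearest anchor is compound 2, whose value in this assay is 1.8 ug/mL, and compound 4 shares the ethylsulfanyl group of that compound. Compound 4 is therefore expected to land near that anchor, estimated at 3 ug/mL with a range of 1 ug/mL to 10 ug/mL. A further entry without a number would not be surprising.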

Compound 4, half-maximal inhibitory concentration: 9.7 ug/mL
The estimate for compound 4 lay 3.2-fold (0.51 log units) below the measured number, within the range that was stated.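

In this assay the series now has its first readable change, a 5.4-fold higher number from compound 2 to compound 4 (0.73 log units; beyond the scatter) with ethylsulfanyl held constant, which shows that the group on the carbonyl carbon matters in this read-out, though this rests on a single pair. The step from compound 3 to compound 4 cannot be read, as compound 3 is recorded as "not determined" (no result reported) and not as a number, so the exchange of ethoxycarbonyl for methyl on a saturated chain carbon bound to a sulfur still has no size. No supporting measurement accompanies these compounds that could account for the change seen between compound 2 and compound 4.

From the compounds shown here alone, it remains open how an amine or a longer chain on the carbonyl carbon would read in this assay and whether the values would fall between those of the methyl and phenyl pair or outside them. Also open, going by these compounds, are the effect of a carboxylic acid in place of ethoxycarbonyl on the saturated chain carbon bound to a sulfur and whether the gap between methyl and phenyl persists when ethylsulfanyl is replaced.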